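Fluoro added to the core of an aminoflavone-type inhibitor

This account rests on a few compounds, and the source may have more. Where it says the series, first, only, none or still open, it means among the compounds named here.

Measured compounds:
- Compound 1, `Nc1ccc(-c2cc(=O)c3c(N)c(Cl)ccc3o2)cc1`: 3.9 nM
- Compound 2, `Nc1ccc(-c2cc(=O)c3c(N)cccc3o2)cc1`: 7.3 nM
- Compound 3, `Cc1ccc(N)c2c(=O)cc(-c3ccc(N)c(F)c3)oc12`: 15 nM

In a functional assay on MCF7 cells (Homo sapiens) for inhibition, in the absence of a further agent (on this read-out higher numbers stand for weaker inhibition and lower numbers for stronger inhibition), compound 2 gives 7.3 nM. Among the three measured numbers compound 2 stands second highest: compound 1 lies a short step away, within the scatter, while compound 3 gives a higher number that lies beyond the scatter.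

Compound 4, `Nc1ccc(-c2cc(=O)c3c(N)ccc(F)c3o2)cc1`, has not yet been measured. Compared with compound 2 it differs by fluoro in place of hydrogen on an aromatic carbon, on the core ring rather than on the aniline ring.

Within the data shown here, only one measured step changes a single halogen on the core: a 1.9-fold higher number from compound 1 to compound 2 (0.27 log units; within the scatter), which remained within the scatter. That step concerns a different halogen at a different position, so it can only suggest that a small halogen on this ring does not move the number much. Among the measured compounds shown here, no measured pair shows the fluoro at the position compound 4 carries it, so there is no direct precedent.

The expectation for this assay is therefore a step of a 1.0-fold lower number from compound 2 to compound 4 (0.02 log units; within the scatter), that is, no change beyond the scatter. Compound 4 is estimated at 7 nM, with a range from 3 nM to 17 nM.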

Compound 4, half-maximal inhibitory concentration: 6.9 nM
Compound 4: the middle estimate sits 1.0-fold (0.01 log units) above what was measured, within the range that was stated.
By their numbers in this assay, from the lowest: compounds 1, 4 and 2 (each within the scatter of the next); then compound 3.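

Replacing hydrogen with fluoro on this aromatic carbon, para to an amino group and ortho to a fused ring, gives a 1.1-fold lower number from compound 2 to compound 4 (0.02 log units; within the scatter) in this assay, so compound 2 and compound 4 cannot be told apart here. Among these compounds, this is the first direct reading at this place on the shared core, and it shows that the position accepts one fluorine atom with no change beyond the scatter, whereas the earlier step, a 1.9-fold higher number from compound 1 to compound 2 (0.27 log units; within the scatter), concerned chloro at a different place. Taken together, these two single-place steps show that neither of these halogen changes on the core moves the number beyond the scatter, although nothing shown here gives a reason why a fluoro at this place leaves the number where it is.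

The reading covers only hydrogen and fluoro at this place, so a single small atom says little about how much room there is for a larger or differently built group. A methoxy group, an amine or a carboxylic acid on the same carbon could leave the number within the scatter or shift it well beyond, and the compounds shown do not tell which.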